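The source may hold more compounds than are shown below. What is called first, only, known or untested is meant among the compounds shown, and "the series" means these compounds.

Measured in an in vivo ADME assay on the whole organism (strain Sprague-Dawley) for pharmacokinetics, with Rattus norvegicus as the target; a higher number here means that more of the compound sits outside the plasma, a lower number that more of the compound stays in the plasma:

- Compound 1 `O=C1[C@@H](NS(=O)(=O)/C=C/c2ccc(Cl)s2)CCN1c1ccc(C2CCCN2)cc1F`: 0.7 L/kg
- Compound 2 `O=C1[C@@H](NS(=O)(=O)c2ccc3cc(Cl)ccc3c2)CCN1c1ccc(C2CCCN2)cc1F`: 1.9 L/kg

Compound 2 holds the higher of the two numbers in this assay. Going by the values given here, the only measured step is a 2.7-fold higher number from compound 1 to compound 2 (0.43 log units; beyond the scatter), a modest change beyond the scatter, made on the sulfonyl sulfur. Compound 3 `O=C1[C@@H](NS(=O)(=O)c2ccc3c(Cl)c[nH]c3c2)CCN1c1ccc(C2CCCN2)cc1F` keeps the shared core and changes the same place again: 3-chloro-1H-indol-6-yl in place of 6-chloronaphthalen-2-yl on a sulfonyl sulfur. It carries 3-chloro-1H-indol-6-yl in place of 6-chloronaphthalen-2-yl on a sulfonyl sulfur.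

That single step shows that a swap at this place can move the number, but it involved a different pair of groups, so it offers only a rough guide to size and no firm direction. Among the compounds with values here, the data hold no measured example of the incoming group. The only other reference point is compound 1 at 0.7 L/kg, so a slight fall is expected rather than a rise. The estimated change is a 1.4-fold lower number from compound 2 to compound 3 (0.13 log units; within the scatter), which would stay within the scatter. For compound 3 the expected value in this assay is 1.4 L/kg, with an estimated range from 0.7 L/kg to 2.8 L/kg.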

Compound 3, volume of distribution at steady state: 0.8 L/kg
The estimate for compound 3 lay 1.8-fold (0.24 log units) above the measured number; measured number inside the range.
By their numbers in this assay, from the lowest: compounds 1 and 3 (each within the scatter of the next); then compound 2.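

In this assay, a 2.4-fold lower number from compound 2 to compound 3 (0.38 log units; beyond the scatter), so a second swap on the sulfonyl sulfur also moves the number beyond the scatter, this time downward on leaving 6-chloronaphthalen-2-yl. The other new step, a 1.1-fold higher number from compound 1 to compound 3 (0.06 log units; within the scatter), puts 3-chloro-1H-indol-6-yl and 2-(5-chlorothiophen-2-yl)ethenyl within the scatter of each other, so among these three groups only 6-chloronaphthalen-2-yl stands apart, with its steps to both others beyond the scatter. The data given offer no measured basis for explaining this difference.

The three compounds differ only in the group on the sulfonyl sulfur, so they leave open how the number would respond to a change elsewhere in the shared core. They also leave open whether 3-chloro-1H-indol-6-yl, which has 1 hydrogen-bond donor where 6-chloronaphthalen-2-yl has 0, would stay close to compound 3 or move toward compound 2 if a methyl group replaced the hydrogen on its ring nitrogen.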